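Methoxy-to-hydroxy step on a styryl diketone and its isoxazole analogue

This account rests on a few compounds, and the source may have more. Where it says the series, first, only, none or still open, it means among the compounds named here.

Measured so far:
- compound 1, `COc1ccc(/C=C/C(=O)CC(C)=O)cc1`: 44600 nM
- compound 2, `COc1ccc(/C=C/c2cc(C)no2)cc1`: 76400 nM
- compound 3, `Cc1cc(/C=C/c2ccc(O)cc2)on1`: 44200 nM

All three numbers come from a functional assay on S1 cells (Homo sapiens) for cytotoxicity, read by MTT assay, with a stated time of 72 h; a higher number here means a weaker inhibitor, a lower number a stronger inhibitor. In this assay compound 1 gives 44600 nM and compound 3 gives 44200 nM; compound 2 gives 76400 nM. The three values sit close to one another, and no ordering among them is claimed.

One pair of measured compounds differs in a single place: from compound 2 to compound 3 the change is hydrogen in place of methyl on an oxygen on an aromatic ring, and the step it made is a 1.7-fold lower number from compound 2 to compound 3 (0.24 log units; within the scatter). The difference between the core of compound 1 and the core of compound 2 is not broken down here.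

The unmeasured compound 4, `CC(=O)CC(=O)/C=C/c1ccc(O)cc1`, stands to compound 1 as compound 3 stands to compound 2: the change is hydrogen in place of methyl on an oxygen on an aromatic ring. The place lines of the two changes agree word for word, so this is the same change carried onto the other core. For the measured compounds named here, only one earlier example of it exists, and that example stayed within the scatter.

Compound 4 is therefore expected to give an estimate of 30000 nM in this assay, with a likely range from 12000 nM to 80000 nM. This rests on compound 1 giving 44600 nM and on the earlier step of a 1.7-fold lower number from compound 2 to compound 3 (0.24 log units; within the scatter), so the expected step is a 1.5-fold lower number from compound 1 to compound 4 (0.17 log units; within the scatter), a step that is itself expected to stay within the scatter.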

Compound 4, half-maximal inhibitory concentration: 10600 nM
Compound 4: middle estimate off by 2.8-fold (0.45 log units), on the high side; the measured number lies below the stated range.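

In this assay, for the compounds shown here, the change from methoxy to hydroxy on the core of compound 1 gives a 4.2-fold lower number from compound 1 to compound 4 (0.62 log units; beyond the scatter), a modest step and the only one of the pair that clears the scatter. Set side by side, the two steps cannot be told apart, so this series gives no sign that the size of the change depends on the core: the same change on two cores in this assay, a 1.7-fold lower number (0.24 log units; within the scatter) from compound 2 to compound 3 and a 4.2-fold lower number (0.62 log units; beyond the scatter) from compound 1 to compound 4, 2.4-fold (0.39 log units) apart, within the scatter of two such steps. This does not show that the change carries over with a fixed size, since two cores are too few to establish that, and one step within the scatter and one beyond it leave the size poorly defined; a real difference between the cores remains possible, though these values cannot resolve it.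

The compounds shown place only methyl or hydrogen on that oxygen, which leaves open what a longer chain such as ethyl on the oxygen would do in this assay, or an amine or a carboxylic acid in place of the methoxy group. Also open, on these data alone, is whether compound 4 keeps its place relative to compound 1 in any cell line other than the one used here.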